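Dropping the chloro: step from compound 2 to compound 3

The source may hold more compounds than are shown below. What is called first, only, known or untested is meant among the compounds shown, and "the series" means these compounds.

Measured in a functional assay, read by spectrophotometry, with a stated time of 15 min, tested at 80 ug/mL; a lower number here means a weaker effect, a higher number a stronger effect of the compound at the concentration tested:
- compound 1 `Cc1ccc(-c2csc(N/N=C/c3ccc(Cl)cc3Cl)n2)cc1`: 84.2%
- compound 2 `Clc1ccc(-c2csc(N/N=C/c3ccc(Cl)cc3Cl)n2)cc1`: 83.1%

Compound 2 and compound 1 sit within the scatter of each other, the step being a number 1.1 percentage points lower from compound 1 to compound 2 (within the scatter). Compound 3 `Clc1ccc(/C=N/Nc2nc(-c3ccccc3)cs2)c(Cl)c1` differs from compound 2 in one place: hydrogen in place of chloro on an aromatic carbon. Among the compounds with values here, the only step measured on this series, a number 1.1 percentage points lower from compound 1 to compound 2 (within the scatter), touched the same aromatic carbon and stayed within the scatter, so a substituent swap there has so far left this assay unmoved. Compound 3 is therefore expected to show no step beyond the scatter, a number 2.1 percentage points lower from compound 2 to compound 3 (within the scatter). The estimate for compound 3 is 81%, within 68% to 90%.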

Compound 3, a percentage reported as inhibition, at one concentration (the size of the read-out at that concentration, not a potency): 83.1%
Compound 3: the middle estimate sits 2.1 percentage points below what was measured, and the stated range covers the measured number.
By their numbers in this assay, from the lowest: compounds 2, 3 and 1 (each within the scatter of the next).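

Taking the substituent off entirely (4-chlorophenyl to phenyl) gives no change at the digits printed from compound 2 to compound 3 (within the scatter) in this assay, and hydrogen in place of methyl gives a number 1.1 percentage points lower from compound 1 to compound 3 (within the scatter) there. This position therefore needs no substituent to keep the read-out: hydrogen, methyl and chloro all lie within the scatter of one another. Nothing available explains this insensitivity.

As far as these compounds go, whether an amine, a carboxylic acid or a longer alkyl chain here would move the read-out stays open. So does whether the same insensitivity holds when the shared core is changed elsewhere.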